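Swapping the aryl group on a fatty acid receptor agonist

The compounds below may be only part of what the source reports. "The series", "measured", "known", "first", "only" and "open" are said of these compounds alone.

Within the data shown here, compound 2 `CC#CC(CC(=O)O)c1ccc(OCc2ccn3cc(-c4ccc(CC)cc4)nc3c2)cc1` is one of two compounds measured in an assay on isolated protein for agonist activity at Free fatty acid receptor 1 (Homo sapiens); a lower number here means that less compound is needed, a higher number that more compound is needed for the effect. In this assay compound 2 gives 671 nM. Among the measured compounds shown here, the only neighbour is compound 1 `CC#CC(CC(=O)O)c1ccc(OCc2ccn3cc(-c4ccc(C5CCCCC5)cc4)nc3c2)cc1`, which in this assay gives 559 nM; the two numbers lie within the scatter of each other, so neither can be called more or less potent.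

Compound 3 `CC#CC(CC(=O)O)c1ccc(OCc2ccn3cc(-c4cccc(C)c4)nc3c2)cc1` is not yet measured. Its change from compound 2 is 3-methylphenyl in place of 4-ethylphenyl on an aromatic carbon. For the measured compounds named here, the one step already known, a 1.2-fold higher number from compound 1 to compound 2 (0.08 log units; within the scatter), exchanged a cyclohexyl for an ethyl on the same aromatic carbon and left the number within the scatter. Going by the values given here, that step suggests the group on that phenyl ring can be varied without a clear effect, but no measured step shows what moving a small alkyl to a different position of the phenyl ring does.

On this basis compound 3 is expected to give about 800 nM in this assay, with a plausible range from 350 nM to 2000 nM. The expected step from compound 2 is a 1.2-fold higher number from compound 2 to compound 3 (0.08 log units; within the scatter), most likely within the scatter.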

Compound 3, half-maximal effective concentration: 1510 nM
The estimate for compound 3 lay 1.9-fold (0.28 log units) below the measured number; the measured number falls inside the stated range.
By their numbers in this assay, from the lowest: compounds 1 and 2 (each within the scatter of the next); then compound 3.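

In this assay, among these compounds, the exchange of 4-ethylphenyl for 3-methylphenyl brings a 2.3-fold higher number from compound 2 to compound 3 (0.35 log units; beyond the scatter) and so gives the first step at this position that lies beyond the scatter. The exchange of 4-cyclohexylphenyl for 3-methylphenyl likewise brings a 2.7-fold higher number from compound 1 to compound 3 (0.43 log units; beyond the scatter) even though the earlier swap of cyclohexyl for ethyl on the same phenyl ring changed nothing that could be told from the scatter, so the group here cannot be varied freely: among these three compounds, 4-cyclohexylphenyl and 4-ethylphenyl both need less compound than 3-methylphenyl. No measurement at hand explains this difference.

The step changes two things at once, the place of the alkyl group on the phenyl ring and its length, so only a comparison with 4-methylphenyl and 3-ethylphenyl could separate the two. On these data alone, it also remains open how a phenyl ring carrying something other than a plain carbon group, such as a methoxy group or an amine, would behave at this position.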